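The source may hold more compounds than are shown below. What is called first, only, known or untested is meant among the compounds shown, and "the series" means these compounds.

In an ADME assay on HepG2 cells (Homo sapiens) for cytotoxicity, read by luminescence, CellTiter-Glo and ATP content, with a stated time of 72 h (on this read-out lower numbers stand for an effect already at smaller amounts and higher numbers for an effect only at larger amounts of compound), compound 1 `COc1ccc(F)cc1CNCCCNc1ccnc2cc(Cc3cc(C)cc(C)c3)ccc12` gives 940 nM. Compound 2 `COc1ccc(F)cc1CNCCCNc1ccnc2cc(Oc3ccccc3)ccc12` differs from it by a phenoxy in place of the 3,5-dimethylbenzyl, and in this assay compound 2 gives 1500 nM. The step of a 1.6-fold higher number from compound 1 to compound 2 (0.20 log units; within the scatter) is the only one measured so far. Among the two numbers to hand, compound 2 is therefore the one whose only neighbour, compound 1, lies within the scatter of it, so nothing separates the two compounds on this read-out.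

Compound 3 `COc1ccc(F)cc1CNCCCNc1ccnc2cc(Oc3ccccc3OC)ccc12` carries one further change: methoxy in place of hydrogen on an aromatic carbon. Among the compounds with values here, no measured step bears directly on this change; the step from compound 1 to compound 2 exchanged one whole pendant group for another and did not involve a methoxy, and it stayed within the scatter in any case. There is thus nothing in the measured pairs that would point to a shift in either direction, and the step of no change at the digits printed from compound 2 to compound 3 (within the scatter) is expected to stay within the scatter. Compound 3 is accordingly estimated at 1500 nM, with a range from 600 nM to 3800 nM.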

Compound 3, half-maximal effective concentration: 6400 nM
Estimate against measurement, compound 3: 4.3-fold (0.63 log units) below, and the stated range ends below it.
By their numbers in this assay, from the lowest: compounds 1 and 2 (each within the scatter of the next); then compound 3.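

In this assay the pendant phenoxy ring turns out to be sensitive to a small substitution. A single methoxy, ortho to a large group on this six-membered aromatic ring, gives a 4.3-fold higher number from compound 2 to compound 3 (0.63 log units; beyond the scatter) and so moves the number beyond the scatter, whereas the exchange of one whole pendant group for another gave only a 1.6-fold higher number from compound 1 to compound 2 (0.20 log units; within the scatter) and left the compounds unseparated. The 2-methoxyphenoxy group also stands apart from the 3,5-dimethylbenzyl group, with a 6.8-fold higher number from compound 1 to compound 3 (0.83 log units; beyond the scatter) on this read-out, but no measurement offered here accounts for either step, so the data fix their size and direction and give no reason for them.

The compounds shown leave open whether this step belongs to the methoxy itself or to any substituent in that place, a question that a fluorine, a hydroxyl or an ethoxy on the same carbon would address. Going by these compounds, it also remains open whether a methoxy elsewhere on the phenoxy ring, or on the pendant ring of compound 1, would move the number in the same direction.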